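The source may hold more compounds than are shown below. What is called first, only, known or untested is meant among the compounds shown, and "the series" means these compounds.

Of the compounds shown here, three built on one shared core have been tested in a functional assay on the whole organism (strain Wistar) for inhibition, with Rattus norvegicus as the target, read by paw edema, with a stated time of 3 h, at a dose of 100 mg/kg; a higher number here means more inhibition at the dose given (going by the name of the read-out), a lower number less inhibition. Compound 1 `COc1cc2c(cc1OC)C(CC(=O)Nc1ccc(Br)cc1)CC2` gives 43.5%. Compound 2 `COc1cc2c(cc1OC)C(CC(=O)Nc1cccc(C)c1)CC2` gives 37.7%, and compound 3 `COc1cc2c(cc1OC)C(CC(=O)Nc1ccc([N+](=O)[O-])cc1)CC2` gives 37.7%. On these numbers compound 2 stands level with compound 3 at the digits shown, the two together forming the lowest pair of the three, and the step of a number 5.8 percentage points lower from compound 1 to compound 2 (within the scatter) lies within the scatter, so no real separation between any two of them can be claimed.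

Compound 4 `COc1cc2c(cc1OC)C(CC(=O)Nc1ccncc1)CC2` differs from compound 2 in a single place: pyridin-4-yl in place of 3-methylphenyl on an amide-type nitrogen. The two measured steps both change the ring carried by that amide-type nitrogen, namely a number 5.8 percentage points lower from compound 1 to compound 2 (within the scatter) and a number 5.8 percentage points lower from compound 1 to compound 3 (within the scatter), and both stay within the scatter. Neither of them, however, exchanges a ring carbon for a ring nitrogen, so the present change is only indirectly covered. With every measured change at that ring having left the read-out essentially where it was, the expectation is a step of a number 0.7 percentage points lower from compound 2 to compound 4 (within the scatter), that is, no movement beyond the scatter in either direction. Compound 4 is therefore estimated at 37%, with a range from 22% to 50%.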

Compound 4, a percentage reported as inhibition, in the whole organism at one dose (the size of the read-out at that dose, not a potency): 42%
For compound 4 the middle estimate is 5 percentage points below the measured one; measured number inside the range.
By their numbers in this assay, from the lowest: compounds 2, 3, 4 and 1 (each within the scatter of the next).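

For the compounds shown here, the swap of 3-methylphenyl for pyridin-4-yl puts a ring nitrogen, and with it a hydrogen-bond acceptor, into the ring on the amide-type nitrogen for the first time, and in this assay it gives a number 4.3 percentage points higher from compound 2 to compound 4 (within the scatter) as the measured result. Set against 4-bromophenyl, the same pyridin-4-yl ring gives a number 1.5 percentage points lower from compound 1 to compound 4 (within the scatter) as its step, so a ring nitrogen at this place, like the earlier methyl, bromo and nitro groups on a carbon-only ring, has produced no change beyond the scatter in these four compounds. Nothing available explains why the read-out holds steady here.

From the compounds shown here alone, all four compounds carry a six-membered aromatic ring at this place, so it remains open whether a carboxylic acid or a dimethylamino group on that ring, a saturated cyclohexyl ring, or a plain butyl chain in its stead would move the read-out beyond the scatter. Going by these compounds alone, each compound also has only one reading at one dose, which leaves open how the four would compare at other doses.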